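A few compounds are considered here, and "the series" means these few. Any claim that something is new, unique, unknown or untested is made for them only; others in the source may bear on it.

Measured in an ADME assay on the whole organism for inhibition, with Echinochloa crus-galli var. formosensis as the target, with a stated time of 4 days (a lower number here means a stronger inhibitor, a higher number a weaker inhibitor), so far:
- compound 1 `CCCCNc1nc(Cl)nc(N[C@H](C)c2ccccc2)n1` gives 38900 nM
- compound 2 `C[C@H](Nc1nc(Cl)nc(NC(C)(C)C)n1)c1ccccc1` gives 7410 nM

Compound 1 has the higher number of the two and so is the weaker inhibitor, and the gap down to compound 2 lies beyond the scatter. Next comes compound 3 `CC(C)Nc1nc(Cl)nc(N[C@H](C)c2ccccc2)n1`, not yet measured, with isopropyl in place of butyl on a nitrogen on an aromatic ring and the rest of compound 1 unchanged. Within the data shown here, no measured step covers this change, so the data give no direct size for it. Among the measured compounds shown here, the only lower reference is compound 2 at 7410 nM, and a move part of the way towards that value is expected. The expected step is a 2.6-fold lower number from compound 1 to compound 3 (0.41 log units; beyond the scatter) in the direction of stronger inhibition, modestly beyond the scatter. Compound 3 is estimated at 15000 nM, with an expected range of 6000 nM to 40000 nM in this assay for now.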

Compound 3, half-maximal inhibitory concentration: 2000 nM
The estimate for compound 3 lay 7.5-fold (0.88 log units) above the measured number, outside the stated range (below it).
By their numbers in this assay, from the lowest: compound 3; then compound 2; then compound 1.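

In this assay the change to isopropyl in place of butyl, on a nitrogen on an aromatic ring, gives a 19-fold lower number from compound 1 to compound 3 (1.29 log units; beyond the scatter) with the rest of compound 1 unchanged, so the group at this one position can shift the read-out by a large margin. Butylamino to isopropylamino shortens the chain and branches it in a single change, so this step cannot separate the two. No evidence at hand bears on the reason for the size of this step.

The compounds shown leave open whether a straight propyl or ethyl chain, or a cyclopropyl ring, on the same nitrogen would behave like isopropyl or like butyl. They also leave open whether the step carries over when another part of the shared core changes.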